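This account rests on a few compounds, and the source may have more. Where it says the series, first, only, none or still open, it means among the compounds named here.

Of the compounds shown here, two sharing one core have been measured in an assay on isolated protein with muscarinic acetylcholine receptor M5 (Homo sapiens) as the target; a lower number here means that less compound is needed, a higher number that more compound is needed for the effect. Compound 1 `COc1noc2c1CNCCC2` carries a methyl on the ring oxygen and gives 4700 nM. Compound 2 `CC(C)Oc1noc2c1CNCCC2` carries an isopropyl in the same place and gives 110 nM, the lower of the two numbers, so less of compound 2 is needed. Among the measured compounds shown here, the single change between them, a 43-fold lower number from compound 1 to compound 2 (1.63 log units; beyond the scatter), shows that replacing methyl with a larger three-carbon group in this position made a large difference. Compound 3 `C#CCOc1noc2c1CNCCC2` keeps the core of compound 2 and differs only in that (propargyl in place of isopropyl on an oxygen on an aromatic ring). The earlier step bears on this only loosely, since both groups here have three carbons and the earlier step compared groups of different size. The expectation is therefore a modest step of a 2.3-fold higher number from compound 2 to compound 3 (0.36 log units; beyond the scatter), most likely toward a higher number, and compound 3 is estimated at 250 nM, within a range from 50 nM to 1200 nM.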

Compound 3, half-maximal effective concentration: 950 nM
The estimate for compound 3 lay 3.8-fold (0.58 log units) below the measured number, and the stated range covers the measured number.
By their numbers in this assay, from the lowest: compound 2; then compound 3; then compound 1.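

Compound 2 and compound 3 carry groups with the same count of three carbons, yet the swap from isopropyl to propargyl in this assay gives an 8.6-fold higher number from compound 2 to compound 3 (0.94 log units; beyond the scatter) and so shows that carbon count alone does not set the number at this place. Propargyl still keeps part of the advantage over methyl, with a 4.9-fold lower number from compound 1 to compound 3 (0.69 log units; beyond the scatter) as the step, so the order at this oxygen runs isopropyl, then propargyl, then methyl. No measured evidence is available to explain the difference between the two three-carbon groups.

Isopropyl is branched and propargyl holds a triple bond, so the compounds shown cannot tell which of these two features matters. Where an ethyl, a cyclopropyl or a tert-butyl group on the same oxygen would fall in this order also remains open.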